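From compound 3 to a 4-methylphenyl on sulfur

This account rests on a few compounds, and the source may have more. Where it says the series, first, only, none or still open, it means among the compounds named here.

Three measured compounds differ only in the group on a sulfur: compound 1 `Cc1cc(C)cc(SCc2ccc(/C=C/C(=O)Nc3ccccc3N)cc2)c1`, compound 2 `Nc1ccccc1NC(=O)/C=C/c1ccc(CSc2ccc(Cl)cc2)cc1` and compound 3 `Nc1ccccc1NC(=O)/C=C/c1ccc(CSc2ccc(C(F)(F)F)cn2)cc1`. In a functional assay on HeLa cells (Homo sapiens) for inhibition, read by CCK-8 assay, with a stated time of 72 h, tested at 8 uM (a higher number here means more inhibition of growth at the concentration tested, a lower number less inhibition of growth), compound 1 gives 3.39%, compound 2 gives 17.3% and compound 3 gives 6.82%. Compound 3 therefore stands within the scatter of one neighbour and beyond it from the other: the data show a number 3.4 percentage points higher from compound 1 to compound 3 (within the scatter) and a number 10.5 percentage points lower from compound 2 to compound 3 (beyond the scatter).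

Compound 4 `Cc1ccc(SCc2ccc(/C=C/C(=O)Nc3ccccc3N)cc2)cc1` has not yet been measured. It carries 4-methylphenyl in place of 5-(trifluoromethyl)pyridin-2-yl on a sulfur. The closest guide is the modest step between the two carbon-only rings already tested, a number 13.9 percentage points higher from compound 1 to compound 2 (beyond the scatter). The 4-methylphenyl group is expected to fall within that span, which runs from 3,5-dimethylphenyl in compound 1 to 4-chlorophenyl in compound 2. That span also contains compound 3, so no step beyond the scatter is expected. The expected change is a number 3.2 percentage points higher from compound 3 to compound 4 (within the scatter). For compound 4 the estimated value is 10%, with an expected range of 2% to 22%.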

Compound 4, percent growth inhibition at one concentration: 21.7%
Estimate against measurement, compound 4: 11.7 percentage points below; the measured number falls inside the stated range.
By their numbers in this assay, from the lowest: compounds 1 and 3 (each within the scatter of the next); then compounds 2 and 4 (each within the scatter of the next).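

In this assay there is a number 4.4 percentage points higher from compound 2 to compound 4 (within the scatter) when methyl replaces chloro on an aromatic carbon, so a chloro group is not required for the higher number among these sulfur-linked rings. Carrying methyl does not by itself secure that number: there is a number 18.3 percentage points higher from compound 1 to compound 4 (beyond the scatter) with 4-methylphenyl in place of 3,5-dimethylphenyl, and a number 14.9 percentage points higher from compound 3 to compound 4 (beyond the scatter) with 4-methylphenyl in place of 5-(trifluoromethyl)pyridin-2-yl, which separates the four compounds into a lower pair and a higher pair. Nothing available explains these steps.

The compounds shown leave open whether a methoxy group or an amine on the same phenyl ring would join the higher pair. They also leave open whether 4-methylpyridin-2-yl, which keeps the ring nitrogen without trifluoromethyl, would fall with the higher or the lower pair.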